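The source may hold more compounds than are shown below. What is called first, only, known or untested is meant among the compounds shown, and "the series" means these compounds.

In a functional assay on the whole organism for inhibition, with Rattus norvegicus as the target, read by cytopathic effect and paw edema, at a dose of 100 mg/kg by the oral route (on this read-out higher numbers stand for more inhibition at the one dose given (going by the name of the read-out) and lower numbers for less inhibition), three compounds built on one shared core have been measured. Compound 1 `CCOC(=O)c1c(O)c2cccnc2n(-c2ccccc2)c1=O` gives 15.5%, the highest number of the three. Compound 2 `COc1ccc(NC(=O)c2c(O)c3cccnc3n(-c3ccccc3)c2=O)cc1` gives -1.9%, and compound 3 `Nc1ccc(NC(=O)c2c(O)c3cccnc3n(-c3ccccc3)c2=O)cc1` gives 0%. Compound 3 thus stands second of the three: its value and that of compound 2 lie within the usual scatter of each other, while compound 1 sits clearly higher, as the step of a number 15.5 percentage points lower from compound 1 to compound 3 (beyond the scatter) shows. The step of a number 17.4 percentage points lower from compound 1 to compound 2 (beyond the scatter) was of similar size, so exchanging ethoxy on the carbonyl carbon for either of the two arylamino groups cost a modest amount of inhibition.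

Compound 4 `Cc1ccccc1NC(=O)c1c(O)c2cccnc2n(-c2ccccc2)c1=O` differs from compound 3 in one place: 2-methylphenyl in place of 4-aminophenyl on an amide-type nitrogen. The amide-type nitrogen and its carbonyl carbon stay as they are. The measured step that bears on this change is a number 1.9 percentage points higher from compound 2 to compound 3 (within the scatter), in which amino replaced methoxy on an aromatic carbon with no movement beyond the scatter. Given that step, no change beyond the scatter is expected for compound 4, no change at the digits printed from compound 3 to compound 4 (within the scatter). Compound 4 is estimated at 0%, with a range from -10% to 10%.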

Compound 4, a percentage reported as inhibition, in the whole organism at one dose (the size of the read-out at that dose, not a potency): 9.8%
For compound 4 the middle estimate is 9.8 percentage points below the measured one; measured number inside the range.
By their numbers in this assay, from the lowest: compounds 2, 3, 4 and 1 (each within the scatter of the next, the first and the last beyond it).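

On the amide-type nitrogen, the aryl group can now make a difference beyond the scatter: with 2-methylphenyl in place of 4-methoxyphenyl, this assay gives a number 11.7 percentage points higher from compound 2 to compound 4 (beyond the scatter), whereas the earlier exchange of methoxy for amino on the aromatic carbon did not. The picture is not clear-cut, since the change from 4-aminophenyl gives only a number 9.8 percentage points higher from compound 3 to compound 4 (within the scatter), and compound 4 is the one amide here that stays within the scatter of the ethoxy compound, with a number 5.7 percentage points lower from compound 1 to compound 4 (within the scatter). Nothing available here offers an explanation for these numbers.

From the compounds shown here alone, what remains open is whether the methyl group matters at all, which plain phenyl or 4-methylphenyl on the same nitrogen would help to show. A benzyl group there would also test whether the ring must sit directly on the amide-type nitrogen.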